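A methoxy for a chloro, tested on a second core

The source may hold more compounds than are shown below. What is called first, only, known or untested is meant among the compounds shown, and "the series" means these compounds.

Compound 1 `O=C(CSC(=S)N[C@H]1CCOC1=O)Nc1ccc(Cl)cc1` and compound 2 `COc1ccc(NC(=O)CSC(=S)N[C@H]2CCOC2=O)cc1` share one core, while compound 3 `O=C(CCl)Nc1ccc(C(=O)/C=C/c2cccc(Cl)c2)cc1` is built on another; the difference between the two cores is not broken down here. In a functional assay on SMMC-7721 cells (Homo sapiens) for cytotoxicity, read by MTT assay, with a stated time of 72 h (on this read-out higher numbers stand for weaker inhibition and lower numbers for stronger inhibition), compound 1 gives only a limit of the assay, > 128000 nM. In this assay compound 2 likewise gives only a limit, > 128000 nM. The change between them is methoxy in place of chloro on an aromatic carbon, and its size is a step that the two limits leave unreadable from compound 1 to compound 2, since both values sit at the limit of > 128000 nM in this assay, at which 2 of the 3 values shown sit. Among the compounds with values here, compound 3 gives 7760 nM in this assay, the only number among the three.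

Compound 4 `COc1cccc(/C=C/C(=O)c2ccc(NC(=O)CCl)cc2)c1` is not yet measured. It differs from compound 3 by methoxy in place of chloro on an aromatic carbon, the same kind of change as before, though the place is not the same: meta to a large group here, para to a large group in the earlier pair. The measured pair gives no readable size for this change, so the expectation rests on compound 3 alone, whose value is 7760 nM. For compound 4 the expected step is a 1.0-fold higher number from compound 3 to compound 4 (0.01 log units; within the scatter). Compound 4 is therefore estimated at 8000 nM, between 2500 nM and 30000 nM.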

Compound 4, half-maximal inhibitory concentration: 10300 nM
The estimate for compound 4 lay 1.3-fold (0.11 log units) below the measured number; measured number inside the range.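

In this assay, putting methoxy in place of chloro gives a 1.3-fold higher number from compound 3 to compound 4 (0.12 log units; within the scatter), so on the core of compound 3 this change leaves no difference that can be told apart from the usual scatter. On the core of compound 1 the same change cannot be read, since compound 1 and compound 2 each give only a limit of the assay, not a number: the limit of > 128000 nM in this assay, at which 2 of the 4 values shown sit. The series therefore does not show that the change carries from one core to the other. Within the data shown here, only one core gives a readable step, and the change sits at a different place in the two pairs, meta to a large group in the new one.

The compounds shown leave open how an amine, a carboxylic acid or a longer chain such as ethoxy would read at this place on the core of compound 3. They also leave open whether any group on the core of compound 1 would give a readable number in this assay.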